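Swapping the Hydrazone Substituent on a Dichloroindole Nucleoside

The source may report more compounds than this note shows. Statements on the series, on what has been measured and on what is new or still open speak of the compounds shown alone.

Two compounds of a shared core have been examined so far in a functional assay on KB cells (Homo sapiens) for cytotoxicity, read by spectrophotometry and crystal violet staining; a higher number here means a weaker inhibitor, a lower number a stronger inhibitor. Compound 1 `CO/N=C/c1c(Cl)n(C2O[C@H](CO)[C@@H](O)[C@H]2O)c2cc(Cl)c(Cl)cc12` gives 70000 nM. Compound 2 `N/C(S)=N/N=C/c1c(Cl)n(C2O[C@H](CO)[C@@H](O)[C@H]2O)c2cc(Cl)c(Cl)cc12` gives 65000 nM. Among the compounds with values here, the one step between them, a 1.1-fold lower number from compound 1 to compound 2 (0.03 log units; within the scatter), changed nothing beyond the scatter, so the two numbers cannot be told apart and compound 2 stands level with compound 1 rather than apart from it.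

Compound 3 `CN(C)/N=C/c1c(Cl)n(C2O[C@H](CO)[C@@H](O)[C@H]2O)c2cc(Cl)c(Cl)cc12` is the next candidate. It differs from compound 2 in one place: a group of 3 heavy atoms (2 carbon, 1 nitrogen; no ring) in place of a group of 4 heavy atoms (1 carbon, 2 nitrogen, 1 sulfur; no ring), on a double-bonded nitrogen, namely a dimethylamino group entering on the double-bonded nitrogen whose other neighbour is a carbon with a double bond to nitrogen. Within the data shown here, the only measured step that bears on this position is a 1.1-fold lower number from compound 1 to compound 2 (0.03 log units; within the scatter), and it was flat. On that single precedent, a step of no more than the scatter is expected in this assay, in no particular direction, and the estimate for compound 3 is 70000 nM, with a range from 25000 nM to 200000 nM, which corresponds to an expected step of a 1.1-fold higher number from compound 2 to compound 3 (0.03 log units; within the scatter).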

Compound 3, half-maximal inhibitory concentration: 70000 nM
Compound 3: the middle estimate sits on the measured number at the digits printed; the measured number falls inside the stated range.
By their numbers in this assay, from the lowest: compounds 2, 1 and 3 (each within the scatter of the next).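

Compound 3 takes away the group with 2 hydrogen-bond donors and puts dimethylamino, with 0 hydrogen-bond donors, on the double-bonded nitrogen, and the result in this assay is a 1.1-fold higher number from compound 2 to compound 3 (0.03 log units; within the scatter), so for these compounds the donor count on this nitrogen does not separate the numbers. Within the data shown here, the comparison with the methoxy compound gives no change at the digits printed from compound 1 to compound 3 (within the scatter), which means that three different groups at this place now stand level, where the earlier compounds could show this for only two, and the flat result no longer rests on a single pair. Nothing available explains why these groups read alike, so the flatness stands as an observation without a cause.

Whether any group on this double-bonded nitrogen can move the number beyond the scatter stays open, since a carboxylic acid, a primary amine or a longer alkyl chain is not among the compounds shown. Also open, going by these compounds, is whether the same level picture would hold with a ring attached at this place, such as a phenyl group.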